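A Methyl on the Linker Carbon of Compound 3

A few compounds are considered here, and "the series" means these few. Any claim that something is new, unique, unknown or untested is made for them only; others in the source may bear on it.

Compound 1 `CN(Cc1ccc(C(=O)O)cc1)c1ccc(OCc2c(-c3c(Cl)cccc3Cl)noc2C2CC2)nc1C(F)(F)F`: 60%
Compound 2 `CC(Nc1ccc(C(=O)O)cc1)c1ccc(OCc2c(-c3c(Cl)cccc3Cl)noc2C2CC2)nc1C(F)(F)F`: 49%
Compound 3 `O=C(O)c1cccc(OCc2ccc(OCc3c(-c4c(Cl)cccc4Cl)noc3C3CC3)nc2C(F)(F)F)c1`: 41%

Among these three, compound 3 stands lowest in a functional assay on HEK293 cells for agonist activity at Bile acid receptor (Homo sapiens), read by a luciferase reporter; on this read-out lower numbers stand for smaller maximal responses and higher numbers for larger maximal responses. Its distance from compound 2 is small: a number 8 percentage points lower from compound 2 to compound 3 (within the scatter). Its distance from compound 1 is larger: a number 19 percentage points lower from compound 1 to compound 3 (beyond the scatter).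

Compound 4 `CC(Oc1cccc(C(=O)O)c1)c1ccc(OCc2c(-c3c(Cl)cccc3Cl)noc2C2CC2)nc1C(F)(F)F` is the next compound on this path. Compared with compound 3 the change is methyl in place of hydrogen on a saturated chain carbon bound to an aromatic carbon and an oxygen on an aromatic ring.

Among the measured compounds shown here, no measured pair shows exactly this change, a methyl placed on the chain carbon with all else kept. The closest comparison is the step from compound 1 to compound 2, where a methyl also appears on the chain carbon, though the link atom changes at the same time: a number 11 percentage points lower from compound 1 to compound 2 (beyond the scatter). That step was modest and downward. Taken alone it suggests that adding a methyl on the linker carbon is unlikely to raise the maximal response, and may lower it a little.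

For compound 4 the expected result in this assay is therefore 36%, with a likely range from 22% to 50%. This estimate corresponds to a step of a number 5 percentage points lower from compound 3 to compound 4 (within the scatter), which would sit within or just beyond the scatter.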

Compound 4, largest response reached (reported as efficacy), in percent of the reference or control that the assay uses: 49%
Compound 4: the middle estimate sits 13 percentage points below what was measured; low and high end bracket the measured number.
By their numbers in this assay, from the lowest: compounds 3, 2 and 4 (each within the scatter of the next); then compound 1.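

On the saturated chain carbon bound to an aromatic carbon and an oxygen on an aromatic ring, the effect of methyl in place of hydrogen can now be read alone, with the link atom unchanged: in this assay it gives a number 8 percentage points higher from compound 3 to compound 4 (within the scatter) and so shows no change that stands clear of the usual scatter. With the methyl in place, 3-carboxyphenoxy in place of (4-carboxyphenyl)amino on that carbon gives no change at the digits printed from compound 2 to compound 4 (within the scatter) and the replacement of (4-carboxybenzyl)(methyl)amino by 1-(3-carboxyphenoxy)ethyl gives a number 11 percentage points lower from compound 1 to compound 4 (beyond the scatter) as its own modest step. No supporting measurement is available to explain any of these numbers.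

The compounds shown leave open whether a larger group on this chain carbon, such as ethyl or a second methyl, would keep the response in the same range. They also leave open whether the methyl step would read the same with a tetrazole in place of the carboxylic acid, since this single pair describes only one setting.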